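Replacing Benzylamino with Anilino on a Shared Core

The compounds below may be only part of what the source reports. "The series", "measured", "known", "first", "only" and "open" are said of these compounds alone.

Compound 2 `O=C1C=C(NCc2ccccc2)C(=O)c2c1nc1n2[C@H]2OC[C@@H](O)[C@H]2OC1` carries a benzylamino group on its core. In a functional assay on MCF7 cells (Homo sapiens) for inhibition, read by sulforhodamine B assay (a higher number here means a weaker inhibitor, a lower number a stronger inhibitor), compound 2 gives only a limit, > 8000 nM, which is the limit of > 8000 nM in this assay, at which 1 of the 3 values shown sits. Compound 1 `O=C1C(Nc2ccc(I)cc2)=CC(=O)c2c1nc1n2[C@H]2OC[C@@H](O)[C@H]2OC1` carries a (4-iodophenyl)amino group and in this assay gives 3890 nM. Compound 3 `O=C1C(N2CCCC2)=CC(=O)c2c1nc1n2[C@H]2OC[C@@H](O)[C@H]2OC1` gives only a limit, > 16000 nM. Going by the values given here, the one measured step, an at least 4.1-fold higher number from compound 1 to compound 3 (0.61 log units; beyond the scatter), lies beyond the scatter. Compound 4 `O=C1C=C(Nc2ccccc2)C(=O)c2c1nc1n2[C@H]2OC[C@@H](O)[C@H]2OC1` differs from compound 2 by phenyl in place of benzyl on an amine nitrogen. Among the compounds with values here, no measured step matches this change; compound 1 and compound 2 only show that an aryl amine gave a number while a benzyl amine gave a limit. Compound 4 is therefore expected near 6000 nM, between 2500 nM and 16000 nM, an estimated step of an at least 1.3-fold lower number from compound 2 to compound 4 (0.12 log units; that floor lies within the scatter).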

Compound 4, half-maximal inhibitory concentration: > 4000 nM
Compound 4: a limit, no number; the forecaster's own chance of this, stated with the estimate: 40%; the middle value lies beyond the limit too.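

Going by these compounds alone, compound 2 and compound 4 both give only limits, not numbers, so no step between them can be read. The compounds shown leave open whether benzyl or phenyl on the amine nitrogen gives the stronger inhibitor in this assay.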